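Compound 3 to compound 4: methoxy for dimethylamino

The source may report more compounds than this note shows. Statements on the series, on what has been measured and on what is new or still open speak of the compounds shown alone.

In an ADME assay on HPLF cells (Homo sapiens) for cytotoxicity, with a stated time of 24 h (on this read-out lower numbers stand for higher toxicity in this test and higher numbers for lower toxicity in this test), the measured compounds read:
compound 1 `O=C1/C(=C/c2ccccc2)CCC/C1=C\c1ccc([N+](=O)[O-])cc1` gives 282000 nM
compound 2 `O=C1/C(=C/c2ccc(Cl)cc2)CCC/C1=C\c1ccc([N+](=O)[O-])cc1` gives 332000 nM
compound 3 `CN(C)c1ccc(/C=C2\CCC/C(=C\c3ccc([N+](=O)[O-])cc3)C2=O)cc1` gives > 400000 nM

Compound 3 gives only a limit and no number, and it stands at the limit of > 400000 nM in this assay, at which 1 of the 3 values shown sits, in the series. Compound 4 `COc1ccc(/C=C2\CCC/C(=C\c3ccc([N+](=O)[O-])cc3)C2=O)cc1` carries methoxy in place of dimethylamino on an aromatic carbon, para to a large group (methoxy in place of dimethylamino on an aromatic carbon). The same place changes in two measured steps: an at least 1.4-fold higher number from compound 1 to compound 3 (0.15 log units; that floor lies within the scatter) and an at least 1.2-fold higher number from compound 2 to compound 3 (0.08 log units; that floor lies within the scatter) in turn. The chloro change gives a 1.2-fold higher number from compound 1 to compound 2 (0.07 log units; within the scatter) as a further guide. No step beyond the scatter and no clear direction are therefore expected in this assay for this change. The expected move is an at least 1.1-fold lower number from compound 3 to compound 4 (0.07 log units; that floor lies within the scatter) on this estimate. Compound 4 is estimated at 340000 nM with an expected range of 220000 nM to 520000 nM as its likely span.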

Compound 4, half-maximal cytotoxic concentration: > 400000 nM
Compound 4 was reported as a limit; the forecaster's own chance of this, stated with the estimate: 30%; at least 1.1-fold (0.07 log units) between middle value and limit.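

In this assay compound 4 gives > 400000 nM as a limit of the assay and not a number. The steps of an at least 1.2-fold higher number from compound 2 to compound 4 (0.08 log units; that floor lies within the scatter) and an at least 1.4-fold higher number from compound 1 to compound 4 (0.15 log units; that floor lies within the scatter) set floors only, and the step between the two limits cannot be read. At this place on the aromatic ring, methoxy thus ends at the same limit as dimethylamino: the limit of > 400000 nM in this assay, at which 2 of the 4 values shown sit.

Any order between methoxy and dimethylamino stays open. Also open, on these data alone, is whether a carboxylic acid or a longer chain at this place would give a number under the limit.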